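A few compounds are considered here, and "the series" means these few. Any claim that something is new, unique, unknown or untested is made for them only; others in the source may bear on it.

Measured compounds:
Compound 1 `COc1ccc(-n2cnc3cnc(-c4ccc(F)cc4C)cc32)cc1OC` – in an ADME assay on S9 fraction from liver (Mus musculus) for metabolic stability, read by LC-MS, using NADPH, with a stated time of 45 min, tested at 3 uM, in the presence of a further agent that is not named here (a higher number here means that the liver removes a larger share of the compound in one pass, a lower number that the liver removes a smaller share), compound 1 gives 1
Compound 2 `COc1ccc(-n2cnc3cnc(-c4ccc(F)cc4C)cc32)cc1` – in this assay compound 2 gives 1
Compound 3 `Cc1ccc(-n2cnc3cnc(-c4ccc(F)cc4C)cc32)cc1` – in this assay compound 3 gives "not determined" (no result reported)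

Compound 2 stands level with compound 1 in this assay; the step from compound 1 to compound 2, hydrogen in place of methoxy on an aromatic carbon, shows no change at the digits printed from compound 1 to compound 2 (within the scatter). Compound 3 carries no number, so it gives no guidance. Among the compounds with values here, the shared core therefore shows only that a change at this ring, from compound 1 to compound 2, left the read-out unchanged.

The next compound, compound 4 `COc1ccc(-n2cnc3cnc(-c4ccc(F)cc4C)cc32)cc1F`, differs from compound 2 in one place: fluoro in place of hydrogen on an aromatic carbon. Within the data shown here, the only step bearing on it is the one from compound 1 to compound 2, and that step was flat. With both measured values sitting at the same level, no movement beyond the scatter is expected; the read-out of compound 2 also leaves little room upward. Compound 4 is therefore expected to give 0.97, within 0.85 to 1, so that the expected step is a number 0.030 lower from compound 2 to compound 4 (within the scatter).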

Compound 4, hepatic extraction ratio: 1
Compound 4: the middle estimate sits 0.030 below what was measured; the measured number falls inside the stated range.
By their numbers in this assay, from the lowest: compounds 1, 2 and 4 (each within the scatter of the next).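

Within the data shown here, earlier, the only readable change at this aromatic carbon, ortho to a methoxy group, was the loss of a methoxy group. In this assay, a fluoro group in place of hydrogen now gives no change at the digits printed from compound 2 to compound 4 (within the scatter), and a fluoro group in place of methoxy gives no change at the digits printed from compound 1 to compound 4 (within the scatter), so hydrogen, methoxy and fluoro at this carbon all leave the hepatic extraction ratio level within the scatter. No measurement offered here accounts for this flat result.

As far as these compounds go, it remains open whether an amine, a carboxylic acid or a longer chain at this carbon would shift the read-out. From the compounds shown here alone, with compound 1, compound 2 and compound 4 all level, it is also open whether a change elsewhere on the shared core would do so.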